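This account rests on a few compounds, and the source may have more. Where it says the series, first, only, none or still open, it means among the compounds named here.

In an ADME assay on Caco-2 cells (Homo sapiens) for permeability, in the apical to basolateral direction (on this read-out higher numbers stand for higher permeability and lower numbers for lower permeability), compound 3 `Cn1cncc1CN1CC(N(CC2CCN(C(=O)N3CCCC3)CC2)S(=O)(=O)c2ccccn2)Cc2cc(C#N)ccc21` gives 0.6 10^-6 cm/s, the highest of the three numbers recorded so far. Compound 1 `Cn1cncc1CN1CC(N(CC2CCN(S(C)(=O)=O)CC2)S(=O)(=O)c2ccccn2)Cc2cc(C#N)ccc21` gives 0.1 10^-6 cm/s and compound 2 `Cn1cnc(S(=O)(=O)N2CCC(CN(C3Cc4cc(C#N)ccc4N(Cc4cncn4C)C3)S(=O)(=O)c3ccccn3)CC2)c1` gives 0.1 10^-6 cm/s; the step of a 6.0-fold higher number from compound 1 to compound 3 (0.78 log units; beyond the scatter) and the step of a 6.0-fold higher number from compound 2 to compound 3 (0.78 log units; beyond the scatter) both lie beyond the scatter, while the step of no change at the digits printed from compound 1 to compound 2 (within the scatter) does not. Compound 4 `CC(C)C(=O)N1CCC(CN(C2Cc3cc(C#N)ccc3N(Cc3cncn3C)C2)S(=O)(=O)c2ccccn2)CC1` keeps the shared core and differs from compound 3 in one place only: isopropyl in place of pyrrolidin-1-yl on a carbonyl carbon. Among the measured compounds shown here, none of the measured steps touches this carbonyl carbon; the two steps that moved the numbers exchanged the whole group on the amine nitrogen in the ring, so they offer no direct guide to swapping pyrrolidin-1-yl for isopropyl. For the measured compounds named here, with no measured step bearing on this exchange, the expectation is a step that stays within the scatter, written as no change at the digits printed from compound 3 to compound 4 (within the scatter). Compound 4 is therefore estimated at 0.6 10^-6 cm/s, with a range from 0.3 10^-6 cm/s to 1.5 10^-6 cm/s.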

Compound 4, apparent permeability: 0.5 10^-6 cm/s
Compound 4: the middle estimate sits 1.2-fold (0.08 log units) above what was measured; low and high end bracket the measured number.
By their numbers in this assay, from the lowest: compounds 1 and 2 (each within the scatter of the next); then compounds 4 and 3 (each within the scatter of the next).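

In this assay, the carbonyl carbon on the ring nitrogen accepts isopropyl in place of pyrrolidin-1-yl with a 1.2-fold lower number from compound 3 to compound 4 (0.08 log units; within the scatter) on record, so giving up the ring and going from 5 heavy atoms to 3 leaves the number within the scatter. The earlier gain therefore does not need the pyrrolidine ring, since isopropylcarbonyl in place of the two sulfonyl groups gives a 5.0-fold higher number from compound 2 to compound 4 (0.70 log units; beyond the scatter) and a 5.0-fold higher number from compound 1 to compound 4 (0.70 log units; beyond the scatter) as well. Among these four compounds, compound 3 and compound 4, the two with a carbonyl on that nitrogen, both stand apart from the two with a sulfonyl there.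

The data shown offer no measurement that explains these differences. Going by these compounds, whether a longer chain, an amine or a carboxylic acid on this carbonyl carbon would keep the number at this level remains open.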